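A few compounds are considered here, and "the series" means these few. Any claim that something is new, unique, unknown or untested is made for them only; others in the source may bear on it.

In a physicochemical assay for solubility, read by mass spectrometry, in phosphate buffer, with a stated time of 24 h, at pH 7.4 (a higher number here means a more soluble compound, a lower number a less soluble compound), compound 1 (`O=C(Nc1ccc(OC(F)(F)F)cc1)NC1CCN(C(=O)C2CCOC2)CC1`) gives 29 ug/mL and compound 2 (`O=C(Nc1ccc(C(F)(F)F)cc1)NC1CCN(C(=O)c2cc[nH]c2)CC1`) gives 1.8 ug/mL. Compound 2 therefore holds the lower of the two numbers, and the gap between them lies beyond the scatter. Compound 3 (`O=C(Nc1ccc(OC(F)(F)F)cc1)NC1CCN(C(=O)c2cc[nH]c2)CC1`) has trifluoromethoxy in place of trifluoromethyl on an aromatic carbon of compound 2: trifluoromethoxy in place of trifluoromethyl on an aromatic carbon. Among the measured compounds shown here, no measured pair shows this change, so in this assay no step beyond the scatter is expected, in either direction. The estimated change is a 1.1-fold higher number from compound 2 to compound 3 (0.05 log units; within the scatter). For compound 3 the expected value is 2 ug/mL, with an estimated range from 0.7 ug/mL to 6 ug/mL.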

Compound 3, solubility: 43 ug/mL
Compound 3: the middle estimate sits 22-fold (1.33 log units) below what was measured; measured number above the stated range.
By their numbers in this assay, from the lowest: compound 2; then compounds 1 and 3 (each within the scatter of the next).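

In this assay, among the compounds shown here, trifluoromethoxy in place of trifluoromethyl on an aromatic carbon, para to a large group, gives a 24-fold higher number from compound 2 to compound 3 (1.38 log units; beyond the scatter) and is the first measured pair to isolate this change. With trifluoromethoxy held fixed, 1H-pyrrol-3-yl in place of oxolan-3-yl on a carbonyl carbon gives a 1.5-fold higher number from compound 1 to compound 3 (0.17 log units; within the scatter) and so shows no step beyond the scatter. Nothing measured here bears on the cause of the large step. On these data alone, whether that step also holds with oxolan-3-yl on the carbonyl carbon remains open. As far as these compounds go, how a methoxy or a chlorine would read on the same aromatic carbon is also open.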